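This account rests on a few compounds, and the source may have more. Where it says the series, first, only, none or still open, it means among the compounds named here.

Compound 1 `COc1ncnc2c1c(-c1ccccc1)cn2[C@@H]1O[C@H](CO)[C@@H](O)[C@H]1O` gives > 100000 nM in an ADME assay on BJ cells (Homo sapiens), read by MTT assay, with a stated time of 72 h (on this read-out higher numbers stand for weaker inhibition and lower numbers for stronger inhibition), which is a limit of the assay and not a number.
Compound 2 `C#Cc1cn([C@@H]2O[C@H](CO)[C@@H](O)[C@H]2O)c2ncnc(OC)c12` gives 98400 nM in this assay.
Compound 3 `COc1nc(N)nc2c1c(-c1ccco1)cn2[C@@H]1O[C@H](CO)[C@@H](O)[C@H]1O` gives > 100000 nM in this assay, again a limit rather than a number.

Compound 3 therefore stands at the upper edge of what was measured, the place where most of the values shown sit (the limit of > 100000 nM in this assay, at which 2 of the 3 values shown sit). Going by the values given here, the only step measured between compounds that differ in one place is an at least 1.0-fold lower number from compound 1 to compound 2 (0.00 log units; that floor lies within the scatter), and since compound 1 is itself at a limit, that step is only a floor and lies within the scatter.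

Compound 4 `COc1ncnc2c1c(-c1ccco1)cn2[C@@H]1O[C@H](CO)[C@@H](O)[C@H]1O` differs from compound 3 by hydrogen in place of amino on an aromatic carbon. No measured step removes an amino group, so nothing shown bears directly on this change; the one measured step, an at least 1.0-fold lower number from compound 1 to compound 2 (0.00 log units; that floor lies within the scatter), concerns a different position and says only that a swap there shifted nothing beyond the scatter. Every measured compound sits at or close to the limit of this assay, so the expectation for compound 4 is a weak number or again only a limit. Compound 4 is estimated at 100000 nM, with a range from 50000 nM to 300000 nM. That estimate means an expected step of a number no higher from compound 3 to compound 4 (the limit leaves the size open), within the scatter.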

Compound 4, half-maximal inhibitory concentration: 430 nM
Compound 4: middle estimate off by 230-fold (2.37 log units), on the high side; measured number outside the range, below it.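

In this assay, the position between two ring nitrogen atoms turns out to matter a great deal: with furan-2-yl held fixed, hydrogen in place of amino gives an at least 230-fold lower number from compound 3 to compound 4 (2.36 log units; beyond the scatter), which makes compound 4 the strongest of the four compounds shown. Going by these compounds alone, the group on the other aromatic carbon also counts, in a way the earlier compounds could not show: furan-2-yl in place of ethynyl gives a 230-fold lower number from compound 2 to compound 4 (2.36 log units; beyond the scatter), and furan-2-yl in place of phenyl gives an at least 230-fold lower number from compound 1 to compound 4 (2.36 log units; beyond the scatter), whereas ethynyl in place of phenyl had shifted nothing beyond the scatter. The steps starting from compound 1 and compound 3 are only floors, and the true drops may be larger, because both of those compounds start from a limit of the assay: the limit of > 100000 nM in this assay, at which 2 of the 4 values shown sit.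

The compounds shown leave open whether amino alone raises the number at this position, or whether a methyl group or a chlorine atom there would do the same. They also leave open whether another ring in place of furan-2-yl, such as thiophene or pyridine, would give a number as low as that of compound 4.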